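Notes on the enone series: aryl swap on the chain

This account rests on a few compounds, and the source may have more. Where it says the series, first, only, none or still open, it means among the compounds named here.

Measured so far in a functional assay on BGC-823 cells (Homo sapiens) for cytotoxicity, read by MTT assay; on this read-out higher numbers stand for weaker inhibition and lower numbers for stronger inhibition:
- compound 1 `COc1cccc(/C=C/C(=O)c2sc(Nc3cccc(C)c3)nc2C)c1`: a limit only, > 25000 nM
- compound 2 `COc1cccc(/C=C/C(=O)c2sc(Nc3ccccc3)nc2C)c1`: 14300 nM

Compound 1 stands at the limit of this assay (the limit of > 25000 nM in this assay, at which 1 of the 2 values shown sits), so only a floor is known for it. Compound 2 gives 14300 nM in this assay. For the measured compounds named here, the one measured step, an at least 1.7-fold lower number from compound 1 to compound 2 (0.24 log units; that floor lies within the scatter), concerns the aryl on the amine nitrogen and not the aryl on the chain.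

Compound 3 `Cc1cccc(Nc2nc(C)c(C(=O)/C=C/c3ccccc3Cl)s2)c1` differs from compound 1 by 2-chlorophenyl in place of 3-methoxyphenyl on a double-bonded chain carbon bound to a double-bonded chain carbon. Going by the values given here, no measured step touches this part of the shared core, so the step from compound 1 to compound 2 gives no direct guide to the size or direction of the change in this assay. With compound 1 known only as a limit, the expectation for compound 3 is kept near that limit and broad. Compound 3 is expected to give about 25000 nM in this assay, estimated between 8000 nM and 80000 nM, which means an expected step of a number no higher from compound 1 to compound 3 (the limit leaves the size open).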

Compound 3, half-maximal inhibitory concentration: 24200 nM
The estimate for compound 3 lay 1.0-fold (0.01 log units) above the measured number; measured number inside the range.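

For the compounds shown here, the change from 3-methoxyphenyl to 2-chlorophenyl on a double-bonded chain carbon bound to a double-bonded chain carbon gives the first step at this position in this assay: an at least 1.0-fold lower number from compound 1 to compound 3 (0.01 log units; that floor lies within the scatter). Compound 3 supplies a number where compound 1 gave none, but this floor does not separate the two compounds beyond the scatter, so no direction can be assigned to the change. The full size of the step cannot be read because compound 1 is a limit and not a number: the limit of > 25000 nM in this assay, at which 1 of the 3 values shown sits.

From the compounds shown here alone, whether 2-chlorophenyl would shift the number when the phenyl of compound 2 stands on the amine nitrogen remains open. Also open, going by these compounds, is how a chain aryl carrying a carboxylic acid or a dimethylamino group would read in this assay.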